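Sulfonamide nitrogen substitution and cytotoxicity in a cyclic series

A few compounds are considered here, and "the series" means these few. Any claim that something is new, unique, unknown or untested is made for them only; others in the source may bear on it.

Measured so far:
Compound 1 `O=C1c2ccccc2N(COCc2ccccc2)S(=O)(=O)N1Cc1ccccc1` gives 25 ug/mL
Compound 2 `O=C1c2ccccc2NS(=O)(=O)N1Cc1ccccc1` gives > 200 ug/mL
Compound 3 `CC(=O)OCCOCN1C(=O)c2ccccc2NS1(=O)=O` gives > 200 ug/mL

In a functional assay on CCRF-CEM cells (Homo sapiens) for cytotoxicity (on this read-out higher numbers stand for lower toxicity in this test and lower numbers for higher toxicity in this test), compound 2 sits at a limit of the test rather than at a number. Compound 3, which carries 2-acetoxyethoxy in place of phenyl on the chain carbon bound to the amide-type nitrogen, also sits at that limit, so a step that the two limits leave unreadable from compound 2 to compound 3. Compound 4 `O=C1c2ccccc2N(COCCO)S(=O)(=O)N1Cc1ccccc1` differs from compound 2 by (2-hydroxyethoxy)methyl in place of hydrogen on a sulfonamide nitrogen in a ring. For the measured compounds named here, the one measured step that touches this nitrogen is an at least 8.0-fold higher number from compound 1 to compound 2 (0.90 log units; beyond the scatter), where removing the (benzyloxy)methyl group raised the number out of the measured range and onto (the limit of > 200 ug/mL in this assay, at which 2 of the 3 values shown sit). Putting a group back onto that nitrogen, now the shorter (2-hydroxyethoxy)methyl group, is therefore expected to move the number back downward, though how far the new group tracks the older one is open. The account estimates compound 4 at 100 ug/mL, within 30 ug/mL to 200 ug/mL, which is expected to mean an at least 2.0-fold lower number from compound 2 to compound 4 (0.30 log units; that floor lies within the scatter).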

Compound 4, half-maximal cytotoxic concentration: 89 ug/mL
Estimate against measurement, compound 4: 1.1-fold (0.05 log units) above, and the stated range covers the measured number.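

In this assay the step of an at least 2.2-fold lower number from compound 2 to compound 4 (0.35 log units; beyond the scatter) shows that a group on this sulfonamide nitrogen in a ring lowers the number even without the phenyl end of compound 1, so the lowering does not belong to (benzyloxy)methyl alone. The step of a 3.6-fold higher number from compound 1 to compound 4 (0.55 log units; beyond the scatter) adds that the far end of the chain also counts, with hydroxymethyl in place of phenyl giving a readable difference at this nitrogen. The first of these steps is a floor and not a full size: the limit of > 200 ug/mL in this assay, at which 2 of the 4 values shown sit.

On these data alone, whether an amine, a carboxylic acid or a longer chain on this nitrogen would sit closer to compound 1 or to compound 2 stays open. Also open, as far as these compounds go, is whether the same lowering would appear with the 2-acetoxyethoxy chain of compound 3 on the other ring nitrogen.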